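The compounds below may be only part of what the source reports. "The series", "measured", "known", "first", "only" and "open" are said of these compounds alone.

Working notes on the series. In a functional assay on HeLa cells (Homo sapiens) for inhibition, read by CCK-8 assay, with a stated time of 48 h (a lower number here means a stronger inhibitor, a higher number a weaker inhibitor), compound 1 `O=S(=O)(NCCNC(=S)Nc1cccc(Cl)c1)c1ccc(-c2ccccc2OCc2cccc(O)c2)s1` gives 10700 nM and compound 2 `O=S(=O)(NCCNC(=S)Nc1cccc(Cl)c1)c1ccc(-c2ccccc2OCc2ccccc2)s1` gives 8400 nM. Compound 3 `COc1ccc(Oc2ccccc2-c2ccsc2S(=O)(=O)N2CCN(C(=O)Nc3cccc([N+](=O)[O-])c3)CC2)cc1OC` gives only a limit in this assay, > 50000 nM.

Among the compounds with values here, compound 1 and compound 2 are the only two with numbers, and they lie within the scatter of each other, so compound 2 holds no clear place ahead of compound 1. Hydrogen in place of hydroxy on an aromatic carbon gives a 1.3-fold lower number from compound 1 to compound 2 (0.11 log units; within the scatter).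

Compound 4 `O=C(NCCNS(=O)(=O)c1ccc(-c2ccccc2OCc2ccccc2)s1)Nc1cc(Cl)cc(Cl)c1` is the next to be read. The difference from compound 2 is a group of 11 heavy atoms (7 carbon, 1 nitrogen, 1 oxygen, 2 chlorine; one six-membered aromatic ring of carbon only) in place of a group of 10 heavy atoms (7 carbon, 1 nitrogen, 1 sulfur, 1 chlorine; one six-membered aromatic ring of carbon only), on an amine nitrogen; (3,5-dichlorophenyl)carbamoyl enters on an amine nitrogen whose other neighbour is a saturated chain carbon.

Within the data shown here, no measured step covers this exchange. Among the measured compounds shown here, the one measured step, a 1.3-fold lower number from compound 1 to compound 2 (0.11 log units; within the scatter), concerns a different group and offers only weak guidance, so no shift beyond the scatter is expected in this assay, and no direction can be assigned with confidence. The expected change is a 1.1-fold higher number from compound 2 to compound 4 (0.03 log units; within the scatter), an estimate that stays within the scatter. With so little support, the range is kept wide. For compound 4 the estimated value is 9000 nM, with an expected range of 3000 nM to 30000 nM.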

Compound 4, half-maximal inhibitory concentration: > 20000 nM
Compound 4 gave a limit, no number (the forecaster's own chance of this, stated with the estimate: 10%); middle value at least 2.2-fold (0.34 log units) from the limit.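

Compound 4 gives only a limit in this assay, > 20000 nM, and this is not a number. Within the data shown here, on the amine nitrogen whose other neighbour is a saturated chain carbon, the entry of (3,5-dichlorophenyl)carbamoyl gives an at least 2.3-fold higher number from compound 2 to compound 4 (0.37 log units; beyond the scatter), so this position responds to exchange in a way that the only earlier step, a 1.3-fold lower number from compound 1 to compound 2 (0.11 log units; within the scatter), could not show, since that step concerned a different place and stayed within the scatter. The step fixes a direction and a smallest size, not a true size, and it rests on a limit: the limit of > 20000 nM in this assay, at which 1 of the 4 values shown sits.

The exchange alters the sulfur, oxygen and chlorine counts of the group together, and the compounds shown do not separate these changes, so it stays open whether the loss follows the oxygen for sulfur, the second chlorine or only their combination. Also open, going by these compounds, is how a simple phenylcarbamoyl group or a small acetyl group on the same amine nitrogen would read, and whether any group there gives a number lower than that of compound 2, 8400 nM.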